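Adding a Second Chlorine to the Chlorophenyl Ring

The source may hold more compounds than are shown below. What is called first, only, known or untested is meant among the compounds shown, and "the series" means these compounds.

Compound 2 `COc1cc(CN(CC(C)C)C(CC(=O)O)c2ccc(Cl)cc2)ccc1OCCN1C(=O)CCC1=O` gives 34 nM in an assay on CHO cells for displacement of a labelled ligand from C-X-C chemokine receptor type 3 (Homo sapiens), with a stated time of 60 min (on this read-out higher numbers stand for weaker inhibition and lower numbers for stronger inhibition), and compound 1 `COc1cc(CN(CC(C)C)C(CC(=O)O)c2ccc3c(c2)CCO3)ccc1OCCN1C(=O)CCC1=O` gives 41 nM; the two values lie within the scatter of each other. Compound 3 `COc1cc(CN(CC(C)C)C(CC(=O)O)c2ccc(Cl)c(Cl)c2)ccc1OCCN1C(=O)CCC1=O` carries chloro in place of hydrogen on an aromatic carbon. Going by the values given here, only one measured step touches that ring: a 1.2-fold lower number from compound 1 to compound 2 (0.08 log units; within the scatter), which exchanged the whole ring system and left the number essentially unchanged. A single added chloro group is expected to move compound 3 little, giving an estimated 1.4-fold lower number from compound 2 to compound 3 (0.13 log units; within the scatter). Compound 3 is therefore estimated at 25 nM, with a range from 10 nM to 70 nM.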

Compound 3, half-maximal inhibitory concentration: 143 nM
Estimate against measurement, compound 3: 5.7-fold (0.76 log units) below, and the stated range ends below it.
By their numbers in this assay, from the lowest: compounds 2 and 1 (each within the scatter of the next); then compound 3.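

In this assay, the added chloro group gives a 4.2-fold higher number from compound 2 to compound 3 (0.62 log units; beyond the scatter), so this single atom, placed ortho to a chloro group and meta to a large group, counts for more than the whole ring exchange between the two earlier compounds. The 3,4-dichlorophenyl compound also stands apart from the fused ring of the first compound, with a 3.5-fold higher number from compound 1 to compound 3 (0.54 log units; beyond the scatter), and the change is therefore not confined to a comparison with the 4-chlorophenyl group. Nothing available accounts for this loss. On these data alone, whether a fluoro, methyl or methoxy group on this same aromatic carbon would give a step of like size stays open.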